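The source may hold more compounds than are shown below. What is called first, only, known or untested is meant among the compounds shown, and "the series" means these compounds.

Compound 1 `Cc1ccc(S(=O)(=O)Oc2cccc(/C=C(\C#N)C(=O)Nc3nnc(-c4cccs4)s3)c2)cc1`: 25%
Compound 2 `N#C/C(=C\c1cccc(NS(=O)(=O)c2ccc(F)cc2)c1)C(=O)Nc1nnc(-c2cccs2)s1`: 22%

In a functional assay on RS4-11 cells (Homo sapiens) for inhibition, read by CCK-8 assay, with a stated time of 48 h, tested at 20 uM (on this read-out higher numbers stand for more inhibition of growth at the one concentration tested and lower numbers for less inhibition of growth), compound 2 gives 22%, which is within the scatter of compound 1 at 25%, so the two cannot be told apart. Compound 3 `COc1ccc(S(=O)(=O)Nc2cccc(/C=C(\C#N)C(=O)Nc3nnc(-c4cccs4)s3)c2)cc1` differs from compound 2 by methoxy in place of fluoro on an aromatic carbon. Going by the values given here, only one measured step bears on this change, a number 3 percentage points lower from compound 1 to compound 2 (within the scatter). That step is small, and it does not test methoxy. With so little to go on, no shift beyond the scatter is expected, and the estimated step is a number 3 percentage points higher from compound 2 to compound 3 (within the scatter). Compound 3 is expected at 25%, with an estimated range of 12% to 40%.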

Compound 3, percent growth inhibition at one concentration: 40%
The estimate for compound 3 lay 15 percentage points below the measured number; low and high end bracket the measured number.
By their numbers in this assay, from the lowest: compounds 2 and 1 (each within the scatter of the next); then compound 3.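

In this assay the swap from 4-fluorophenyl to 4-methoxyphenyl gives a number 18 percentage points higher from compound 2 to compound 3 (beyond the scatter) and is the only step shown that lies beyond the scatter. It shows that the group on this aromatic carbon, para to a large group, can change growth inhibition, which the step between compound 1 and compound 2 could not show. Nothing measured here bears on the reason for this step. As far as these compounds go, it remains open how an amine, a hydroxy group or a longer ether such as ethoxy would read at this carbon. From the compounds shown here alone, whether methoxy would bring a similar rise on the sulfonate ester of compound 1 also remains open.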